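From acetyl to 4-(tert-butyl)benzyl in compound 4

The compounds below may be only part of what the source reports. "The series", "measured", "known", "first", "only" and "open" are said of these compounds alone.

In a functional assay on KYSE-450 cells (Homo sapiens) for inhibition, read by CCK-8 assay, with a stated time of 48 h (a higher number here means a weaker inhibitor, a lower number a stronger inhibitor), compound 2 `COc1ccc(CN(C(=O)CSC(=S)N2CCN(C(C)=O)CC2)c2cc(OC)c(OC)c(OC)c2)cc1` gives 370 nM. Compound 3 `COc1ccc(CN(C(=O)CSC(=S)N2CCN(C(=O)OC(C)(C)C)CC2)c2cc(OC)c(OC)c(OC)c2)cc1` gives 250 nM, which cannot be told apart from compound 2, while compound 1 `COc1ccc(CN(C(=O)CSc2nc3ccccc3o2)c2cc(OC)c(OC)c(OC)c2)cc1` gives 840 nM, clearly separated from compound 2.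

Compound 4 `COc1ccc(CN(C(=O)CSC(=S)N2CCN(Cc3ccc(C(C)(C)C)cc3)CC2)c2cc(OC)c(OC)c(OC)c2)cc1` carries 4-(tert-butyl)benzyl in place of acetyl on an amine nitrogen in a ring. Among the compounds with values here, two measured steps bear on this change. The closer one, a 1.5-fold lower number from compound 2 to compound 3 (0.17 log units; within the scatter), places tert-butoxy in place of methyl on a carbonyl carbon and stays within the scatter. The other, a 2.3-fold lower number from compound 1 to compound 2 (0.36 log units; beyond the scatter), is a modest step that changes the whole group on sulfur. Within the data shown here, no measured compound has a benzyl group on that nitrogen, so this evidence is indirect.

On this basis, no shift beyond the scatter is expected in this assay, and the expected step is a 1.2-fold lower number from compound 2 to compound 4 (0.09 log units; within the scatter). The estimate for compound 4 is 300 nM, with an expected range from 100 nM to 900 nM.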

Compound 4, half-maximal inhibitory concentration: 2140 nM
Estimate against measurement, compound 4: 7.1-fold (0.85 log units) below, outside the stated range (above it).
By their numbers in this assay, from the lowest: compounds 3 and 2 (each within the scatter of the next); then compound 1; then compound 4.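

In this assay, the amine nitrogen in the ring turns out not to be a place where any group is tolerated: a 5.8-fold higher number from compound 2 to compound 4 (0.76 log units; beyond the scatter) and an 8.6-fold higher number from compound 3 to compound 4 (0.93 log units; beyond the scatter), both beyond the scatter. The earlier pair had shown only that acetyl and tert-butoxycarbonyl, each joined to that nitrogen through a carbonyl, read within the scatter of each other, whereas 4-(tert-butyl)benzyl, with no carbonyl and with an aromatic ring, separates clearly from both. No measurement shown here accounts for this rise.

Since this one change removes the carbonyl and brings in both the aromatic ring and the tert-butyl group, the step cannot be assigned to any one of them. As far as these compounds go, whether a plain benzyl or a benzoyl on that nitrogen would read like compound 4 or like compound 2 remains open.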